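The source may hold more compounds than are shown below. What is called first, only, known or untested is meant among the compounds shown, and "the series" means these compounds.

Measured so far in a functional assay on cells (Cancer cell lines, Homo sapiens) for cytotoxicity, read by sulforhodamine B assay, with a stated time of 48 h; a higher number here means a weaker inhibitor of growth, a lower number a stronger inhibitor of growth:
compound 1 `O=C1N=C(N2N=C(c3ccccc3)CC2c2ccccc2O)S/C1=C1/C(=O)Nc2ccc(Br)cc21` gives 460 nM
compound 2 `COc1ccc(C2CC(c3ccccc3)=NN2C2=NC(=O)/C(=C3\C(=O)Nc4ccc(Br)cc43)S2)cc1` gives 390 nM

Compound 2 holds the lower of the two numbers shown, but the gap to compound 1 is small: a 1.2-fold lower number from compound 1 to compound 2 (0.07 log units; within the scatter). That step replaced the substituted phenyl on the saturated ring carbon, and the assay did not respond to it beyond its usual scatter.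

Compound 3 `COc1ccc(C2=NN(C3=NC(=O)/C(=C4\C(=O)Nc5ccc(Br)cc54)S3)C(c3ccc(OC)cc3)C2)cc1` is not yet measured. It differs from compound 2 in one place: methoxy in place of hydrogen on an aromatic carbon, on the phenyl that sits on the unsaturated ring carbon, para to a large group; cut one bond further out, the change reads phenyl to 4-methoxyphenyl. Among the measured compounds shown here, the only measured step touches a different ring, so no direct precedent exists for this exact change. What the data do show is that altering the substituent pattern on one of the two phenyl rings left the number essentially unchanged, and the same outcome is the most reasonable expectation here.

Compound 3 is therefore expected to give about 400 nM in this assay, within a range of 200 nM to 850 nM. The expected step is a 1.0-fold higher number from compound 2 to compound 3 (0.01 log units; within the scatter), no more than the scatter.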

Compound 3, concentration for total growth inhibition: 25300 nM
Compound 3: middle estimate off by 63-fold (1.80 log units), on the low side; measured number above the stated range.
By their numbers in this assay, from the lowest: compounds 2 and 1 (each within the scatter of the next); then compound 3.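

In this assay, putting methoxy in place of hydrogen on an aromatic carbon, para to a large group, turns phenyl into 4-methoxyphenyl and gives a 65-fold higher number from compound 2 to compound 3 (1.81 log units; beyond the scatter) as the result, so an addition of only 2 heavy atoms at this position can sharply weaken growth inhibition. The earlier change elsewhere in the molecule, a 1.2-fold lower number from compound 1 to compound 2 (0.07 log units; within the scatter) as its result, stayed within the scatter, so the lack of response at that place does not extend to this one. No measurement shown here explains the large step between compound 2 and compound 3.

Among the compounds shown here, what remains open is whether this position rejects substituents in general or methoxy in particular, since hydrogen and methoxy are the only two groups compared there. A fluorine or chlorine atom, a hydroxyl, an amine, a carboxylic acid or a longer chain such as ethoxy at the same place would show whether the number rises with any added group, and whether some groups leave it close to that of compound 2.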